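Removing the phenoxy group from a sulfonamide series

This account rests on a few compounds, and the source may have more. Where it says the series, first, only, none or still open, it means among the compounds named here.

Measured compounds:
compound 1, `COc1ccc(NS(=O)(=O)c2ccc(N3CCNC3=O)cc2)cc1`, 800 nM
compound 2, `CCCCOc1ccc(NS(=O)(=O)c2ccc(N3CCNC3=O)cc2)cc1`, 630 nM
compound 3, `O=C1NCCN1c1ccc(S(=O)(=O)Nc2cccc(Oc3ccccc3)c2)cc1`, 200 nM

In a functional assay on HT-29 cells (Homo sapiens) for antiproliferative activity, read by sulforhodamine B assay, with a stated time of 48 h (on this read-out higher numbers stand for weaker inhibition and lower numbers for stronger inhibition), compound 3 gives the lowest number of the three, and its gap to compound 2 and to compound 1 lies beyond the scatter in both cases. Compound 4, `O=C1NCCN1c1ccc(S(=O)(=O)Nc2ccccc2)cc1`, differs from compound 3 by hydrogen in place of phenoxy on an aromatic carbon on an aromatic carbon of a six-membered aromatic ring of carbon only, meta to a large group. Among the measured compounds shown here, only one measured step exists, a 1.3-fold lower number from compound 1 to compound 2 (0.10 log units; within the scatter), and it concerns a chain on an ether oxygen rather than the removal of the whole phenoxy group, so it bears on the present step only loosely; it shows that lengthening that chain changed little. For the measured compounds named here, no measured pair shows the effect of taking the group away entirely. Since compound 3, the compound carrying phenoxy, stands lowest, compound 4 is expected to give a higher number in this assay, with a step of about a 4.0-fold higher number from compound 3 to compound 4 (0.60 log units; beyond the scatter). The estimate for compound 4 is 800 nM, within a range of 300 nM to 2500 nM.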

Compound 4, half-maximal inhibitory concentration: 280 nM
Estimate against measurement, compound 4: 2.9-fold (0.46 log units) above; measured number below the stated range.
By their numbers in this assay, from the lowest: compounds 3 and 4 (each within the scatter of the next); then compounds 2 and 1 (each within the scatter of the next).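

In this assay, the phenoxy group turns out not to be needed on this aromatic carbon, since replacing it with hydrogen leaves the number within the scatter (a 1.4-fold higher number from compound 3 to compound 4 (0.15 log units; within the scatter)). Hydrogen also gives a modestly lower number in place of butoxy (a 2.3-fold lower number from compound 2 to compound 4 (0.35 log units; beyond the scatter)) and in place of methoxy (a 2.9-fold lower number from compound 1 to compound 4 (0.46 log units; beyond the scatter)), so none of the three ether groups brings a gain over the bare ring, and the two alkyl ethers fall behind it. Nothing available explains why these steps come out as they do. From the compounds shown here alone, it remains open whether any group on this ring can take the number clearly below that of hydrogen, for example a fluorine, an amine or a carboxylic acid. The data also leave open whether a benzyloxy group would behave like phenoxy or like the alkyl ethers.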